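Aryl swap at the saturated ring carbon: compound 4

The source may hold more compounds than are shown below. What is called first, only, known or untested is meant among the compounds shown, and "the series" means these compounds.

Going by the values given here, compound 3 `COc1cc(C2=NN(C(C)=O)C(c3ccccc3C(F)(F)F)O2)cc(OC)c1OC` gives 34.8% in a functional assay on BGC-823 cells (Homo sapiens) for antiproliferative activity, read by MTT assay, tested at 5 uM (on this read-out higher numbers stand for a stronger effect at the one concentration tested and lower numbers for a weaker effect), and stands highest of the three numbers measured so far. Compound 2 `COc1ccc(OC)c(C2OC(c3cc(OC)c(OC)c(OC)c3)=NN2C(C)=O)c1` gives 18.2% in this assay, and compound 1 `COc1ccc(C2OC(c3cc(OC)c(OC)c(OC)c3)=NN2C(C)=O)c(OC)c1` gives -3.1%. The measured steps all concern the aryl group on the same saturated ring carbon: a number 21.3 percentage points higher from compound 1 to compound 2 (beyond the scatter), a number 37.9 percentage points higher from compound 1 to compound 3 (beyond the scatter) and a number 16.6 percentage points higher from compound 2 to compound 3 (beyond the scatter).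

Compound 4 `COc1cc(C2=NN(C(C)=O)C(c3ccc(C(F)(F)F)cc3)O2)cc(OC)c1OC` differs from compound 3 in one place: 4-(trifluoromethyl)phenyl in place of 2-(trifluoromethyl)phenyl on a saturated ring carbon. Among the compounds with values here, the only measured step that moves a substituent around a ring while keeping its kind is the one from compound 1 to compound 2, which was of modest size; the larger steps to compound 3 replaced dimethoxyphenyl with trifluoromethylphenyl and do not bear directly on a move of the trifluoromethyl group. A step of modest size in this assay is therefore expected, direction uncertain, with a slight lean towards a lower number. For compound 4 the expected value is 28%, within 8% to 50%, meaning an expected step of a number 6.8 percentage points lower from compound 3 to compound 4 (within the scatter).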

Compound 4, a percentage reported as inhibition, at one concentration (the size of the read-out at that concentration, not a potency): 3.4%
For compound 4 the middle estimate is 24.6 percentage points above the measured one; the measured number lies below the stated range.
By their numbers in this assay, from the lowest: compounds 1 and 4 (each within the scatter of the next); then compound 2; then compound 3.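

In this assay the placement of the trifluoromethyl group on the phenyl ring matters on its own: with the same atoms joined differently, 4-(trifluoromethyl)phenyl in place of 2-(trifluoromethyl)phenyl gives a number 31.4 percentage points lower from compound 3 to compound 4 (beyond the scatter). The advantage seen earlier over the dimethoxyphenyl groups therefore does not extend to every trifluoromethylphenyl group, as the 4-(trifluoromethyl)phenyl group gives a number 14.8 percentage points lower from compound 2 to compound 4 (beyond the scatter) and a number 6.5 percentage points higher from compound 1 to compound 4 (within the scatter). Nothing at hand accounts for the difference between the two placements.

Open, on these data alone, is whether a nitrile, an amine or a carboxylic acid on the phenyl ring would depend on its placement in the same way. Also open, as far as these compounds go, is how the two trifluoromethyl placements compare when the acetyl group gives way to a longer chain such as butanoyl.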